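Bromo in Place of Methyl: Compound 3 to Compound 4

The source may hold more compounds than are shown below. What is called first, only, known or untested is meant among the compounds shown, and "the series" means these compounds.

Compound 1 `COc1ccc(Nc2nc3ccccc3nc2S(=O)(=O)c2ccc(C)cc2)cc1` gives in a functional assay on PC-3 cells (Homo sapiens) for cytotoxicity, read by MTT assay, with a stated time of 72 h (on this read-out higher numbers stand for weaker inhibition and lower numbers for stronger inhibition), a value that is only a limit of the assay, > 50000 nM. Compound 2 `Cc1ccc(S(=O)(=O)c2nc3ccccc3nc2Nc2ccc(N)cc2)cc1` gives 5000 nM. Compound 3 `Cc1ccc(S(=O)(=O)c2nc3ccccc3nc2Nc2cccc(N)c2)cc1` gives 2000 nM.

Among the two numbers shown, compound 3 stands lowest; a 2.5-fold lower number from compound 2 to compound 3 (0.40 log units; beyond the scatter), and compound 1 sits at the limit of > 50000 nM in this assay, at which 1 of the 3 values shown sits. Compound 4 `Nc1cccc(Nc2nc3ccccc3nc2S(=O)(=O)c2ccc(Br)cc2)c1` differs from compound 3 by bromo in place of methyl on an aromatic carbon. The measured steps all alter the ring on the nitrogen instead: an at least 10-fold lower number from compound 1 to compound 2 (1.00 log units; beyond the scatter), an at least 25-fold lower number from compound 1 to compound 3 (1.39 log units; beyond the scatter), a 2.5-fold lower number from compound 2 to compound 3 (0.40 log units; beyond the scatter). Within the data shown here, none of them touches the 4-methylphenyl group, so they give no direct guide; with no bearing steps, a change no larger than the scatter is expected, so no change at the digits printed from compound 3 to compound 4 (within the scatter) is estimated. Compound 4 is therefore expected to give about 2000 nM, within 700 nM to 6000 nM.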

Compound 4, half-maximal inhibitory concentration: 9010 nM
The estimate for compound 4 lay 4.5-fold (0.65 log units) below the measured number; the measured number lies above the stated range.
By their numbers in this assay, from the lowest: compound 3; then compounds 2 and 4 (each within the scatter of the next). At a limit, above all of these: compound 1.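

The 4-methylphenyl group is not a silent part of the molecule: in this assay, changing it to 4-bromophenyl gives a 4.5-fold higher number from compound 3 to compound 4 (0.65 log units; beyond the scatter). This is the first step shown away from the ring on the nitrogen, and one heavy atom replaced by one other is enough to move the number beyond the scatter. Nothing measured here explains why bromo gives the higher number.

From the compounds shown here alone, it remains open how chloro, an amine or a carboxylic acid would read at this position. Also open, going by these compounds, is whether bromo has the same effect when the nitrogen carries the 4-aminophenyl group of compound 2.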